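The source may hold more compounds than are shown below. What is called first, only, known or untested is meant among the compounds shown, and "the series" means these compounds.

Measured so far in an assay on HEK293 cells for binding affinity to Substance-K receptor (Rattus norvegicus), read by FRET, tested at 10 uM; a lower number here means less inhibition, a higher number more inhibition at the concentration tested (going by the name of the read-out):

- compound 1, `O=C(O)CCCCN(Cc1ccccc1)Cc1ccc2ccccc2c1`, gives 0%
- compound 2, `O=C(CN(Cc1ccccc1)Cc1ccc2ccccc2c1)OCCc1ccccc1`, gives 0%

On the numbers shown, compound 2 stands level with compound 1 at the digits given; the nearest measured neighbour is compound 1, and the two differ by nothing at those digits, which lies within the scatter of this kind of measurement. For the measured compounds named here, neither compound shows any inhibition at the single concentration tested, so the series so far has no measured step between compounds that differ in one place, and no direction of change has yet been seen.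

Compound 3, `O=C(CN(Cc1ccccc1)Cc1ccc2ccccc2c1)OCCO`, is the next compound to be measured. It differs from compound 2 by hydroxy in place of phenyl on a saturated chain carbon, two bonds along the chain from an oxygen next to a carbonyl group.

Going by the values given here, with no measured step to build on, and with both compound 1 and compound 2 giving the same reading in this assay, the expectation for the step from compound 2 to compound 3 is a change of none beyond the scatter, that is no change at the digits printed from compound 2 to compound 3 (within the scatter). Compound 3 is therefore estimated at 0% in this assay, with an expected range from -10% to 10%.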

Compound 3, a percentage reported as inhibition, at one concentration (the size of the read-out at that concentration, not a potency): 0%
For compound 3 middle estimate and measured number coincide at the digits printed, and the stated range covers the measured number.
By their numbers in this assay, from the lowest: compounds 1, 2 and 3 (each within the scatter of the next).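

Readings in this assay stay flat when hydroxy replaces phenyl on a saturated chain carbon, two bonds along the chain from an oxygen next to a carbonyl group: the step reads no change at the digits printed from compound 2 to compound 3 (within the scatter) and adds a case where removing that phenyl brings no inhibition. The (2-hydroxyethoxy)carbonyl in place of 3-carboxypropyl on a saturated chain carbon bound to an amine nitrogen reads the same way, with no change at the digits printed from compound 1 to compound 3 (within the scatter) as its step. For the compounds shown here, with all readings at the same level, these steps show only that neither change produces inhibition at the single concentration tested, and no supporting measurement accounts for this.

On these data alone, whether this position can influence the reading at all remains open, as does the effect of an amine, a primary amide or a longer chain ending in hydroxy on that chain carbon. Changes to the shared core also remain open, as does any reading at another concentration.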